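Same atoms, one double bond left undefined

The source may hold more compounds than are shown below. What is called first, only, known or untested is meant among the compounds shown, and "the series" means these compounds.

In a functional assay on K562 cells (Homo sapiens) for antiproliferative activity, read by MTT assay, with a stated time of 5 days (a higher number here means a weaker inhibitor, a lower number a stronger inhibitor), compound 1 `COc1ccc(C=C(C(=O)c2cc(OC)c(OC)c(OC)c2)c2ccccc2O)cc1` gives 240000 nM, while compound 2 `COc1ccc(/C=C(/C(=O)c2cc(OC)c(OC)c(OC)c2)c2ccccc2O)cc1O` gives 49000 nM, the lower of the two numbers and a gap beyond the usual scatter. Compound 3 `COc1ccc(C=C(C(=O)c2cc(OC)c(OC)c(OC)c2)c2ccccc2O)cc1O` has not yet been measured. It differs from compound 2 in one way only: the two compounds have the same atoms and bonds; at least one stereo element is drawn with a configuration in one of them and without one in the other: 1 of 1 stereo elements differ; a double bond is drawn E in compound 2 and without a configuration in compound 3. With nothing else altered, no step beyond the scatter is expected in this assay, although the undrawn configuration leaves room in either direction. The expected size of the change is a 1.1-fold lower number from compound 2 to compound 3 (0.04 log units; within the scatter). The estimate for compound 3 is 45000 nM, within an expected range from 15000 nM to 140000 nM.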

Compound 3, half-maximal inhibitory concentration: 35000 nM
For compound 3 the middle estimate is 1.3-fold (0.11 log units) above the measured one; low and high end bracket the measured number.
By their numbers in this assay, from the lowest: compounds 3 and 2 (each within the scatter of the next); then compound 1.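

In this assay, leaving the double bond undefined changes little: a 1.4-fold lower number from compound 2 to compound 3 (0.15 log units; within the scatter). Compound 1 and compound 3 differ in one place, so the effect of hydroxy in place of hydrogen on an aromatic carbon can now be read cleanly, as a 6.9-fold lower number from compound 1 to compound 3 (0.84 log units; beyond the scatter). The only difference in the first pair is this: the fact that one of compounds 2 and 3 is drawn with a defined configuration and the other without, at the place where they differ.

On these data alone, whether compound 3 is one double-bond form or a mixture stays unknown, so the form opposite to that of compound 2 cannot be judged. As far as these compounds go, how an amine would compare with this hydroxy also remains open.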